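Chloro for hydrogen on the core of compound 2

This account rests on a few compounds, and the source may have more. Where it says the series, first, only, none or still open, it means among the compounds named here.

Measured compounds:
compound 1, `ClCc1ccccc1Cn1cnc2c(Cl)nc(Cl)nc21`, 150 nM
compound 2, `ClCc1cccc(Cn2cnc3ncnc(Cl)c32)c1`, 3090 nM

Of the compounds shown here, two have been measured in a functional assay on LOX IMVI cells (Homo sapiens) for cytotoxicity, read by sulforhodamine B assay, with a stated time of 48 h; a higher number here means a weaker inhibitor of growth, a lower number a stronger inhibitor of growth. Compound 1 `ClCc1ccccc1Cn1cnc2c(Cl)nc(Cl)nc21` gives 150 nM in this assay. Within the data shown here, compound 2 `ClCc1cccc(Cn2cnc3ncnc(Cl)c32)c1` gives 3090 nM in this assay and thus stands at the highest number of the two, with compound 1 as its only neighbour well beyond the scatter. Among the measured compounds shown here, the two compounds differ in more than one place, so no single step between them can be read off; what they show is simply that the compound with two chloro groups on the core sits at the far lower number.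

Compound 3 `ClCc1cccc(Cn2cnc3nc(Cl)nc(Cl)c32)c1` is not yet measured. It differs from compound 2 by chloro in place of hydrogen on an aromatic carbon. This brings the core of compound 3 to the same two-chloro pattern as compound 1, while the benzyl part stays that of compound 2. Without a measured step for this change alone, the expectation is a drop in number from compound 2 to compound 3 of a 4.4-fold lower number from compound 2 to compound 3 (0.64 log units; beyond the scatter), leaning on the low value of compound 1 150 nM but with wide uncertainty. For compound 3 the estimated value in this assay is 700 nM, within a range from 150 nM to 3000 nM.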

Compound 3, concentration for 50% growth inhibition: 230 nM
Estimate against measurement, compound 3: 3.0-fold (0.48 log units) above; measured number inside the range.
By their numbers in this assay, from the lowest: compounds 1 and 3 (each within the scatter of the next); then compound 2.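

In this assay, among these compounds, chloro in place of hydrogen on the aromatic carbon between two ring nitrogen atoms gives a 13-fold lower number from compound 2 to compound 3 (1.13 log units; beyond the scatter), the first step that can be tied to a single place. The core of compound 1 and compound 3 thus carries this chloro in both, and with it compound 3 at 230 nM and compound 1 at 150 nM lie within the scatter of each other, although the benzyl parts of the two differ; among the compounds shown, the one without this chloro, compound 2, stands apart from the other two. No measurement at hand speaks to the reason for the size of this step.

On these data alone, it remains open whether the gain belongs to chloro itself or would also appear with another group at this position, such as fluoro, methoxy or an amine. The compounds shown also leave open how much the chloromethyl group on the benzyl part contributes, since all three carry it and none has a plain methyl or a hydroxymethyl in its place.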